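The source may report more compounds than this note shows. Statements on the series, on what has been measured and on what is new or still open speak of the compounds shown alone.

Working notes on the amide series. In a functional assay on MGC-803 cells (Homo sapiens) for inhibition, read by MTT assay, with a stated time of 48 h (a lower number here means a stronger inhibitor, a higher number a weaker inhibitor), compound 2 `C/C=C/C=C/C(=O)N(Cc1ccc(OC)c(O)c1)c1cc(OC)c(OC)c(OC)c1` gives 140 nM, the lowest of the three numbers recorded. Compound 1 `C/C=C/C(=O)N(Cc1cc(OC)c(OC)c(OC)c1)c1ccc(OC)c(O)c1` gives 6150 nM in this assay, and compound 3 `COc1cc(NCc2cccc(O)c2)cc(OC)c1OC` gives 57600 nM, so compound 2 stands well apart from both, each gap lying beyond the scatter. No pair among these three differs in a single place, so no isolated step is available.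

Compound 4 `COc1ccc(CN(C(=O)C[Se]C#N)c2cc(OC)c(OC)c(OC)c2)cc1O` has not been measured. It differs from compound 2 as follows: a group of 4 heavy atoms (2 carbon, 1 nitrogen, 1 selenium; no ring) in place of a group of 5 heavy atoms (5 carbon; no ring), on a carbonyl carbon. The remaining framework, the amide-type nitrogen with its two aryl-bearing arms, is unchanged.

The data hold no earlier exchange on the carbonyl carbon, so the size of this step is not anchored. A moderate rise in the number for compound 4 is expected, with the step of a 2.9-fold higher number from compound 2 to compound 4 (0.46 log units; beyond the scatter) likely reaching the edge of the scatter rather than far beyond it. Compound 4 is therefore estimated at 400 nM in this assay, within a range from 80 nM to 3000 nM.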

Compound 4, half-maximal inhibitory concentration: 270 nM
Compound 4: the middle estimate sits 1.5-fold (0.17 log units) above what was measured, within the range that was stated.
By their numbers in this assay, from the lowest: compounds 2 and 4 (each within the scatter of the next); then compound 1; then compound 3.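

On the carbonyl carbon, the group of 4 heavy atoms carrying selenium and a triple bond in place of penta-1,3-dien-1-yl gives, in this assay, a 1.9-fold higher number from compound 2 to compound 4 (0.29 log units; within the scatter). Going by these compounds alone, this is the first readable exchange at this position, and it shows that two quite different groups, one with 2 double bonds and no hydrogen-bond acceptor, the other with 1 triple bond and 1 hydrogen-bond acceptor, cannot be told apart in this assay on the shared core. No measurement shown accounts for this result.

As far as these compounds go, it remains open how a shorter group such as methyl, a longer chain or a phenyl ring would read on the same carbonyl carbon. Also open, from the compounds shown here alone, is whether selenium itself counts, which a thiocyanate-bearing analogue would test.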